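The source may report more compounds than this note shows. Statements on the series, on what has been measured and on what is new or still open speak of the compounds shown alone.

In a functional assay (aorta) with Rattus norvegicus as the target (a higher number here means a weaker inhibitor, a lower number a stronger inhibitor), three compounds have been measured so far:

compound 1, `CCCN(CCC)CCCOc1ccc(S(=O)(=O)c2c(C)cn3ccccc23)cc1`, giving 957 nM
compound 2, `CCCN(CCC)CCCOc1ccc(S(=O)(=O)c2c(CC)cn3ccccc23)cc1`, giving 150 nM
compound 3, `CCc1cn2ccccc2c1S(=O)(=O)c1ccc(OCCCNC(C)(C)C)cc1`, giving 413 nM

Compound 2 differs from compound 1 by methyl in place of hydrogen on a saturated chain carbon bound to an aromatic carbon, and that change brought a 6.4-fold lower number from compound 1 to compound 2 (0.80 log units; beyond the scatter). Compound 3 keeps the core of compound 2 but carries a different amine, and in this assay this gave a 2.8-fold higher number from compound 2 to compound 3 (0.44 log units; beyond the scatter). The difference between the cores of compound 1 and compound 3 is not broken down here.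

Compound 4, `CC(C)c1cn2ccccc2c1S(=O)(=O)c1ccc(OCCCNC(C)(C)C)cc1`, remains to be measured. It differs from compound 3 by methyl in place of hydrogen on a saturated chain carbon bound to an aromatic carbon and a saturated chain carbon. Among the measured compounds shown here, this is the same kind of change as the one from compound 1 to compound 2, but not the same: in compound 4 the carbon that gains the methyl is bound to an aromatic carbon and a saturated chain carbon, whereas in compound 2 it is bound to an aromatic carbon only. Resting on a 6.4-fold lower number from compound 1 to compound 2 (0.80 log units; beyond the scatter), but allowing for these different surroundings, one expects a smaller step for compound 4, namely a 1.7-fold lower number from compound 3 to compound 4 (0.22 log units; within the scatter). The estimate for compound 4 in this assay is therefore 250 nM, expected to lie between 100 nM and 700 nM.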

Compound 4, half-maximal inhibitory concentration: 41.8 nM
Beside the measured number, compound 4's estimate is 6.0-fold (0.78 log units) above it; the whole stated range lies above it.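

In this assay, turning ethyl into isopropyl gave a 9.9-fold lower number from compound 3 to compound 4 (0.99 log units; beyond the scatter), and this step agrees with the earlier methyl step on the other core: the same change on two cores in this assay, a 6.4-fold lower number (0.80 log units; beyond the scatter) from compound 1 to compound 2 and a 9.9-fold lower number (0.99 log units; beyond the scatter) from compound 3 to compound 4, 1.5-fold (0.19 log units) apart, within the scatter of two such steps. Across these two pairs the change carried over, lowering the number by a like amount even though the amine differs, dipropylamino in one pair and (tert-butyl)amino in the other, and the carbon that gains the methyl has different surroundings. Among the compounds shown here, this rests on only two pairs in a single assay, so it does not show that the step would hold on any further core or amine, and it does not say why the added methyl lowers the number.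

The compounds shown leave open whether cyclopropyl or a longer chain such as n-butyl in place of the isopropyl would lower the number further. They also leave open what isopropyl would give when paired with the dipropylamino amine of compound 2.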